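The compounds below may be only part of what the source reports. "The series", "measured", "known", "first", "only" and "open" are said of these compounds alone.

Measured compounds in an assay on HEK293 cells for positive allosteric modulation of metabotropic glutamate receptor 2 (Rattus norvegicus), read by thallium flux, with a stated time of 2.5 min; a lower number here means a smaller maximal response, a higher number a larger maximal response:
- compound 1, `COc1cc(C(=O)O)ccc1OCCCCOc1ccc(C(=O)C(C)C)c(O)c1C`: 73.1%
- compound 2, `COC(=O)c1ccc(OCCCCOc2ccc(C(=O)CC3CCCC3)c(O)c2C)cc1`: 12.2%
- compound 3, `Cc1c(OCCCCOc2ccc(C(=O)O)cc2F)ccc(C(=O)CC2CCCC2)c1O`: 83.8%

Compound 1 stands second highest of the three numbers in this assay. Its nearest neighbour is compound 3, whose number lies beyond the scatter above it, and the furthest is compound 2, whose number lies far below it, also beyond the scatter. Within the data shown here, the one step measured between compounds that differ in a single place is a number 71.6 percentage points higher from compound 2 to compound 3 (beyond the scatter), which exchanges the aryl group on the oxygen on a saturated carbon, not the acyl group.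

Compound 4, `COc1cc(C(=O)O)ccc1OCCCCOc1ccc(C(=O)CC(C)C)c(O)c1C`, differs from compound 1 only in the group on the carbonyl carbon: isobutyl in place of isopropyl on a carbonyl carbon. Cut one bond further out, the change reads isopropylcarbonyl to isobutylcarbonyl. Among the measured compounds shown here, no measured step touches this part of the molecule; compound 1 and compound 3 differ in the acyl group as well, but they also differ in the aryl group, so their two values cannot be read as a step for the acyl change alone. With nothing bearing on it, the estimated step of a number 0.1 percentage points lower from compound 1 to compound 4 (within the scatter) is expected to lie within the usual scatter, in no clear direction. Compound 4 is therefore expected to give about 73% in this assay, with a range from 50% to 92%.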

Compound 4, largest response reached (reported as percent of maximum), in percent of the reference or control that the assay uses: 85.7%
Compound 4: the middle estimate sits 12.7 percentage points below what was measured; low and high end bracket the measured number.
By their numbers in this assay, from the lowest: compound 2; then compound 1; then compounds 3 and 4 (each within the scatter of the next).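

In this assay the group on the carbonyl carbon proves not to be silent: with isobutyl in place of isopropyl and the rest of the core of compound 1 unchanged, the response shifts by a number 12.6 percentage points higher from compound 1 to compound 4 (beyond the scatter) and so moves beyond the scatter. Among these compounds, until now the only step that could be read concerned the aryl group on the oxygen on a saturated carbon, namely a number 71.6 percentage points higher from compound 2 to compound 3 (beyond the scatter) and this new step shows that the acyl group also affects the maximal response, although by a smaller amount than that aryl exchange. Nothing available here accounts for the step or links it to any property of the isobutyl group.

As far as these compounds go, whether a longer chain such as n-pentyl, or a ring such as cyclohexyl, on the carbonyl carbon would extend this rise or reverse it remains open. From the compounds shown here alone, the step also rests on a single pair, so it is unknown whether isobutyl in place of isopropyl would give a similar step with another aryl group, such as one carrying a tetrazole in place of the carboxylic acid.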